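An Amide Replaces a Pyrazole on a Fused Core

The source may report more compounds than this note shows. Statements on the series, on what has been measured and on what is new or still open speak of the compounds shown alone.

Compound 1 `Cn1nccc1-c1cccc2c1CCC2c1ncc[nH]1` was examined in a functional assay on CHO cells for agonist activity at Alpha-1B adrenergic receptor (Homo sapiens), read by FLIPR and calcium flux; on this read-out higher numbers stand for an effect only at larger amounts of compound and lower numbers for an effect already at smaller amounts. In this assay compound 1 gives only a limit, > 10000 nM, and not a number. Compound 2 `CS(=O)(=O)Nc1c(Cl)ccc2c1CCCC2c1ncc[nH]1` belongs to the same small set. In this assay compound 2 likewise reaches only the limit of > 10000 nM. Compound 3 `Clc1ccc2c(c1-c1ccn[nH]1)CCC2c1ncc[nH]1` completes the measured group. In this assay compound 3 also stops at the limit of > 10000 nM. Where compound 1 stands can therefore be told only through (the limit of > 10000 nM in this assay, at which 3 of the 3 values shown sit); no measured compound separates itself from the others, and no step between two measured compounds is available.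

Compound 4 `CNC(=O)c1cccc2c1CCC2c1ncc[nH]1` has not yet been measured in this assay. It differs from compound 1 in a single place: methylcarbamoyl in place of 1-methyl-1H-pyrazol-5-yl on an aromatic carbon. Within the data shown here, with every measured value sitting at the limit, there is no measured step from which the size of this change could be read, so the account expects no shift beyond the scatter, and the most likely outcome is that compound 4 again returns only the limit. The estimated step is a number no higher from compound 1 to compound 4 (the limit leaves the size open). Compound 4 is expected to give in this assay about 10000 nM, with a range from 3000 nM to 30000 nM.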

Compound 4, half-maximal effective concentration: > 10000 nM
Compound 4: a limit, no number; the forecaster's own chance of this, stated with the estimate: 80%; the middle value sits exactly at the limit.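

In this assay compound 4 gives > 10000 nM as a limit and not a number. Among these compounds, no step from compound 1 to compound 4 can be read, because both compounds stop at a limit: (the limit of > 10000 nM in this assay, at which 4 of the 4 values shown sit). The compounds shown leave open how far methylcarbamoyl in place of 1-methyl-1H-pyrazol-5-yl on an aromatic carbon moves the read-out, and what would bring a measured number in this assay at all.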